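The source may report more compounds than this note shows. Statements on the series, on what has been measured and on what is new or still open speak of the compounds shown alone.

In an ADME assay on HEp-2 cells (Homo sapiens) for cytotoxicity (a higher number here means that more compound is tolerated, a lower number that less compound is tolerated), compound 1 (`Cc1ccc(NC(=O)[C@@H]2CCCN2S(=O)(=O)c2cccc3cccnc23)cc1`) gives 31700 nM and compound 2 (`O=C(Nc1ccccc1)[C@@H]1CCCN1S(=O)(=O)c1cccc2cccnc12`) gives 35600 nM in the half-maximal cytotoxic concentration read-out. The step of a 1.1-fold higher number from compound 1 to compound 2 (0.05 log units; within the scatter) is the only one between these two. Compound 3 (`Cc1ccnc(C)c1NC(=O)[C@@H]1CCCN1S(=O)(=O)c1cccc2cccnc12`) sits at > 50000 nM in this assay, and this is a limit of the assay, not a number.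

Compound 4 (`Cc1cc(C)cc(NC(=O)[C@@H]2CCCN2S(=O)(=O)c2cccc3cccnc23)c1`) carries 3,5-dimethylphenyl in place of 2,4-dimethylpyridin-3-yl on an amide-type nitrogen. Its aromatic ring is therefore of carbon only, as in compound 1 and compound 2.

The closest measured steps run the opposite way, towards the 2,4-dimethylpyridin-3-yl group: an at least 1.5-fold higher number from compound 1 to compound 3 (0.19 log units; that floor lies within the scatter) and an at least 1.4-fold higher number from compound 2 to compound 3 (0.14 log units; that floor lies within the scatter) are both known only as floors. Among the measured compounds shown here, the methyl step between compound 1 and compound 2 suggests that methyl groups on the phenyl ring need not move the value much, though it covers only one such group.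

A small move to a lower number is expected, back towards compound 1 and compound 2, and it may not clear the scatter. The expected step is an at least 1.6-fold lower number from compound 3 to compound 4 (0.22 log units; that floor lies within the scatter) on this estimate. Compound 4 is estimated at 30000 nM in this assay, with a range from 15000 nM to 50000 nM expected.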

Compound 4, half-maximal cytotoxic concentration: 31300 nM
Estimate against measurement, compound 4: 1.0-fold (0.02 log units) below, within the range that was stated.
By their numbers in this assay, from the lowest: compounds 4, 1 and 2 (each within the scatter of the next). At a limit, above all of these: compound 3.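

In this assay the 3,5-dimethylphenyl group on the amide-type nitrogen cannot be told from phenyl, with a 1.1-fold lower number from compound 2 to compound 4 (0.06 log units; within the scatter) on that change, nor from 4-methylphenyl, with a 1.0-fold lower number from compound 1 to compound 4 (0.01 log units; within the scatter) on that one, so across compound 1, compound 2 and compound 4 the methyl groups on a ring of carbon only show no readable effect at this position. Compound 3 stands at > 50000 nM and this is a limit of the assay, not a number. The change from 2,4-dimethylpyridin-3-yl to 3,5-dimethylphenyl therefore has only a floor, an at least 1.5-fold lower number from compound 3 to compound 4 (0.20 log units; that floor lies within the scatter) being all that can be said, and whether the ring nitrogen of compound 3 separates it from the carbon-only rings at all stays unreadable because of the limit: the limit of > 50000 nM in this assay, at which 1 of the 4 values shown sits.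

Still open, on these data alone, is how far compound 3 lies past its limit, and so whether any real gap exists between it and the other three compounds. Also open, as far as these compounds go, is whether a group of another kind on the phenyl ring at this nitrogen, such as a carboxylic acid or an amine, would move the value in this assay beyond the scatter.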